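Oxamides with a shared core: from a phenylcyclopropyl to a dimethylbenzyl

The source may report more compounds than this note shows. Statements on the series, on what has been measured and on what is new or still open speak of the compounds shown alone.

Compound 1 `C[C@H](NC(=O)C(=O)NCC1(c2ccccc2)CC1)C(=O)N[C@@H](CC(=O)O)C(=O)COc1c(F)c(F)cc(F)c1F` is one of three measured members of a shared core, and in a functional assay on Jurkat cells (Homo sapiens) (a lower number here means a stronger inhibitor, a higher number a weaker inhibitor), compound 1 gives 27 nM, the second highest of the three numbers. Compound 2 `Cc1cccc(CNC(=O)C(=O)N[C@@H](C)C(=O)N[C@@H](CC(=O)O)C(=O)COc2c(F)c(F)cc(F)c2F)c1C` gives 102 nM and compound 3 `Cc1ccc(C)c(CNC(=O)C(=O)N[C@@H](C)C(=O)N[C@@H](CC(=O)O)C(=O)COc2c(F)c(F)cc(F)c2F)c1` gives 11 nM. The measured steps from compound 1 run both ways: a 3.8-fold higher number from compound 1 to compound 2 (0.58 log units; beyond the scatter), while a 2.5-fold lower number from compound 1 to compound 3 (0.39 log units; beyond the scatter); between the two dimethylbenzyl compounds, a 9.3-fold lower number from compound 2 to compound 3 (0.97 log units; beyond the scatter).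

Compound 4 `Cc1ccc(CNC(=O)C(=O)N[C@@H](C)C(=O)N[C@@H](CC(=O)O)C(=O)COc2c(F)c(F)cc(F)c2F)cc1C` is not yet measured. Relative to compound 1 it carries 3,4-dimethylphenyl in place of 1-phenylcyclopropyl on a saturated chain carbon bound to an amide-type nitrogen. The two measured steps away from the 1-phenylcyclopropyl group are the ones that bear on this change, and they point in opposite directions, so the data give no clear direction for a third dimethylphenyl pattern. Compound 4 is therefore expected to land near compound 1, with a step of a 1.1-fold higher number from compound 1 to compound 4 (0.05 log units; within the scatter) that could fall on either side of the scatter. The estimate for compound 4 is 30 nM, within a range from 8 nM to 120 nM.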

Compound 4, half-maximal inhibitory concentration: > 10000 nM
Compound 4 ended at the assay's limit; the forecaster's own chance of this, stated with the estimate: 2%; middle value at least 330-fold (2.52 log units) from the limit.
By their numbers in this assay, from the lowest: compound 3; then compound 1; then compound 2. At a limit, above all of these: compound 4.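

In this assay, the value of compound 4 is a limit and not a number: the limit of > 10000 nM in this assay, at which 1 of the 4 values shown sits. With an at least 370-fold higher number from compound 1 to compound 4 (2.56 log units; beyond the scatter), replacing 1-phenylcyclopropyl on a saturated chain carbon bound to an amide-type nitrogen is shown to be capable of far more than the modest shifts seen among compounds 1, 2 and 3. The arrangement of the two methyl groups alone also has a much larger reach than the earlier dimethylbenzyl pair showed, with an at least 900-fold higher number from compound 3 to compound 4 (2.95 log units; beyond the scatter) and an at least 98-fold higher number from compound 2 to compound 4 (1.99 log units; beyond the scatter).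

The compounds shown leave open whether this loss belongs to the 3,4-dimethylphenyl pattern as a whole or to a single methyl group. A 3-methylbenzyl or 4-methylbenzyl group in the same place would separate these two readings.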